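The source may report more compounds than this note shows. Statements on the series, on what has been measured and on what is new or still open speak of the compounds shown alone.

Compound 1 `Cc1cc(N2CC[C@@H](C)[C@@H](N(C)c3ncnc4[nH]ccc34)C2)n2nc(SCc3ccccc3)nc2n1` gives 14400 nM in a functional assay on BGC-823 cells (Homo sapiens) for inhibition, read by MTT assay, with a stated time of 72 h (a higher number here means a weaker inhibitor, a lower number a stronger inhibitor), the lowest of the three numbers recorded. Compound 3 `Cc1cc(N2CC[C@@H](C)[C@@H](N(C)c3ncnc4[nH]ccc34)C2)n2nc(SCc3ccc(C(F)(F)F)cc3)nc2n1` gives 23300 nM, a step of a 1.6-fold higher number from compound 1 to compound 3 (0.21 log units; within the scatter). Compound 2 `CCCSc1nc2nc(C)cc(N3CC[C@@H](C)[C@@H](N(C)c4ncnc5[nH]ccc45)C3)n2n1` gives 51200 nM, a step of a 3.6-fold higher number from compound 1 to compound 2 (0.55 log units; beyond the scatter). Compound 4 `C#CSc1nc2nc(C)cc(N3CC[C@@H](C)[C@@H](N(C)c4ncnc5[nH]ccc45)C3)n2n1` differs from compound 1 by ethynyl in place of benzyl on a sulfur. Going by the values given here, the one measured step that bears on this is the removal of the aromatic ring from the sulfur substituent in compound 2, where a 3.6-fold higher number from compound 1 to compound 2 (0.55 log units; beyond the scatter) was seen; replacing benzyl with ethynyl on the sulfur is expected to move the number in the same direction, by a modest amount beyond the scatter. Compound 4 is therefore expected to give 40000 nM, within 15000 nM to 120000 nM. The expected step is a 2.8-fold higher number from compound 1 to compound 4 (0.44 log units; beyond the scatter).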

Compound 4, half-maximal inhibitory concentration: 62100 nM
Compound 4: middle estimate off by 1.6-fold (0.19 log units), on the low side, and the stated range covers the measured number.
By their numbers in this assay, from the lowest: compounds 1 and 3 (each within the scatter of the next); then compounds 2 and 4 (each within the scatter of the next).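

In this assay the ethynyl group on the sulfur does not match benzyl or 4-(trifluoromethyl)benzyl, with a 4.3-fold higher number from compound 1 to compound 4 (0.63 log units; beyond the scatter) and a 2.7-fold higher number from compound 3 to compound 4 (0.43 log units; beyond the scatter) both printed as beyond the scatter. Against propyl, ethynyl gives no readable change, with a 1.2-fold higher number from compound 2 to compound 4 (0.08 log units; within the scatter) and so the triple bond does not separate these two compounds. No measurement shown accounts for these steps.

Still open, as far as these compounds go, is whether the aromatic ring or the size of the substituent matters more: a longer alkyl chain such as hexyl, or a pyridylmethyl group on the sulfur, would help separate the two.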